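Cell tolerance from compound 3 to compound 4

The source may report more compounds than this note shows. Statements on the series, on what has been measured and on what is new or still open speak of the compounds shown alone.

Compound 1 `Cc1cc(C)cc(S(=O)(=O)c2c(C(=O)N[C@@H]3CCNC3)[nH]c3ccc(Cl)cc23)c1` gives 37300 nM 
Compound 2 `Cc1cc(C)cc(S(=O)(=O)c2c(C(=O)N[C@@H]3CCN(S(C)(=O)=O)C3)[nH]c3ccc(Cl)cc23)c1` gives 24000 nM 
Compound 3 `Cc1cc(C)cc(S(=O)(=O)c2c(C(=O)N[C@H]3CCN(S(C)(=O)=O)C3)[nH]c3ccc(Cl)cc23)c1` gives 29900 nM 

All three values come from an ADME assay on MT4 cells (Homo sapiens) for cytotoxicity, read by MTT assay, with a stated time of 5 days (a higher number here means that more compound is tolerated, a lower number that less compound is tolerated), and lie close together. Compound 3 sits within the scatter of both others, with a 1.2-fold lower number from compound 1 to compound 3 (0.10 log units; within the scatter) on one side and a 1.2-fold higher number from compound 2 to compound 3 (0.10 log units; within the scatter) on the other, so it holds no distinct place among them.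

Compound 4 `Cc1cc(C)cc(S(=O)(=O)c2c(C(=O)NS(C)(=O)=O)[nH]c3ccc(Cl)cc23)c1` has not yet been measured. The difference is methylsulfonyl in place of 1-(methylsulfonyl)pyrrolidin-3-yl on an amide-type nitrogen, in short methylsulfonyl in place of 1-(methylsulfonyl)pyrrolidin-3-yl on an amide-type nitrogen.

The measured steps bear on this only in part, since none of them removes the ring. Placing methylsulfonyl on the ring nitrogen gave a 1.6-fold lower number from compound 1 to compound 2 (0.19 log units; within the scatter) and also a 1.2-fold lower number from compound 1 to compound 3 (0.10 log units; within the scatter), while the change of configuration alone gave a 1.2-fold higher number from compound 2 to compound 3 (0.10 log units; within the scatter) as its whole effect. On that showing, no step beyond the scatter is expected in this assay, although the loss of the ring leaves the range wide. The expected change is a 1.0-fold higher number from compound 3 to compound 4 (0.00 log units; within the scatter) and no more than that. For compound 4 an estimated 30000 nM is expected, with 11000 nM and 80000 nM as the ends of the range.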

Compound 4, half-maximal cytotoxic concentration: 40200 nM
Estimate against measurement, compound 4: 1.3-fold (0.13 log units) below, within the range that was stated.
By their numbers in this assay, from the lowest: compounds 2, 3, 1 and 4 (each within the scatter of the next).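

In this assay, the ring on this amide-type nitrogen proves unnecessary for the number to stay where it was: methylsulfonyl in place of 1-(methylsulfonyl)pyrrolidin-3-yl removes the five-membered non-aromatic ring and the defined stereocentre, yet gives a 1.3-fold higher number from compound 3 to compound 4 (0.13 log units; within the scatter) and a 1.7-fold higher number from compound 2 to compound 4 (0.22 log units; within the scatter). The same holds with the ring nitrogen unsubstituted, as methylsulfonyl in place of pyrrolidin-3-yl gives a 1.1-fold higher number from compound 1 to compound 4 (0.03 log units; within the scatter). The earlier compounds shown here had tested only the group on the ring nitrogen and the configuration of the ring carbon, whereas this result extends the flat picture to loss of the whole ring, with all four compounds lying within the scatter of one another.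

As far as these compounds go, whether an amine, a carboxylic acid, a longer chain or a phenyl ring on this amide-type nitrogen would also stay within the scatter remains open, as does the effect of any change elsewhere on the shared core. Nothing given here bears on why the number holds across these changes.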